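This account rests on a few compounds, and the source may have more. Where it says the series, first, only, none or still open, it means among the compounds named here.

Within the data shown here, in a functional assay on A549 cells (Homo sapiens) for inhibition, read by sulforhodamine B assay, with a stated time of 72 h (on this read-out higher numbers stand for weaker inhibition and lower numbers for stronger inhibition), compound 3 `Nc1sc(-c2ccc(Cl)cc2)c(-c2ccc(Cl)cc2)c1C(=O)NC1CCC(O)CC1` gives 250 nM, the lowest of the three numbers measured so far. Compound 2 `CC1CCN(C(=O)c2c(N)sc(-c3ccc(Cl)cc3)c2-c2ccc(Cl)cc2)CC1` gives 1750 nM, and compound 1 `Nc1sc(-c2ccc(Cl)cc2)c(-c2ccc(Cl)cc2)c1C(=O)N1CCCCC1` gives 4620 nM. Compound 4 `Nc1sc(-c2ccc(Cl)cc2)c(-c2ccc(Cl)cc2)c1C(=O)N1CCOCC1` changes one group of compound 3, on a carbonyl carbon: morpholin-4-yl in place of (4-hydroxycyclohexyl)amino on a carbonyl carbon. Among the measured compounds shown here, two measured steps bear on this change: an 18-fold lower number from compound 1 to compound 3 (1.27 log units; beyond the scatter) and a 7.0-fold lower number from compound 2 to compound 3 (0.85 log units; beyond the scatter). Both put (4-hydroxycyclohexyl)amino on the carbonyl carbon, and compound 4 takes that group away. A modest to large step toward a higher number is therefore expected in this assay. The expected size is a 12-fold higher number from compound 3 to compound 4 (1.08 log units; beyond the scatter). The estimate for compound 4 is 3000 nM, with an expected range from 1000 nM to 9000 nM.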

Compound 4, half-maximal inhibitory concentration: 1870 nM
The estimate for compound 4 lay 1.6-fold (0.21 log units) above the measured number; the measured number falls inside the stated range.
By their numbers in this assay, from the lowest: compound 3; then compounds 2 and 4 (each within the scatter of the next); then compound 1.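

Taking away (4-hydroxycyclohexyl)amino costs potency (a 7.5-fold higher number from compound 3 to compound 4 (0.87 log units; beyond the scatter)), yet morpholin-4-yl still gives a lower number than piperidin-1-yl (a 2.5-fold lower number from compound 1 to compound 4 (0.39 log units; beyond the scatter)). It also stands level with 4-methylpiperidin-1-yl (a 1.1-fold higher number from compound 2 to compound 4 (0.03 log units; within the scatter)), so two different changes to the piperidin-1-yl ring reach the same level, and neither reaches compound 3. Nothing measured here explains these differences. Which part of (4-hydroxycyclohexyl)amino matters stays open, whether the amide hydrogen, the hydroxyl or the ring, as these never change one at a time in the compounds shown. Plain cyclohexylamino or 4-aminocyclohexylamino on the carbonyl carbon would help separate them.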